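Pendant aryl variation on the shared core: toward compound 4

The source may hold more compounds than are shown below. What is called first, only, known or untested is meant among the compounds shown, and "the series" means these compounds.

Three compounds of the series carry the same fused core and differ only in the pendant aryl group. Compound 1 `CCC1=C(O)c2c(oc(-c3ccc(CC(C)C)cc3)cc2=O)C(CC)(CC)C1=O` gives 17.4 uM in a functional assay on KBVIN cells (Homo sapiens) for antiproliferative activity, read by sulforhodamine B assay, with a stated time of 3 days; a lower number here means that less compound is needed, a higher number that more compound is needed for the effect. Compound 2 `CCCOc1ccc(-c2cc(=O)c3c(o2)C(CC)(CC)C(=O)C(CC)=C3O)cc1` gives 29.2 uM in the same assay, and the change of propoxy in place of isobutyl on an aromatic carbon gives a 1.7-fold higher number from compound 1 to compound 2 (0.22 log units; within the scatter). Compound 3 `CCC1=C(O)c2c(oc(-c3cccc(C)c3)cc2=O)C(CC)(CC)C1=O` gives 3.69 uM and so stands lowest of the three numbers; its gap to compound 1 and to compound 2 is beyond the scatter in both cases.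

Compound 4 `CCC1=C(O)c2c(oc(-c3ccc(OC)c(Cl)c3)cc2=O)C(CC)(CC)C1=O` is not yet measured. It differs from compound 3 by 3-chloro-4-methoxyphenyl in place of 3-methylphenyl on an aromatic carbon. For the measured compounds named here, no measured step swaps a substituted phenyl of this kind for 3-methylphenyl, so the only step that bears on it is the one from compound 1 to compound 2, where an oxygen-linked group replaced an alkyl group on the pendant ring and the number barely moved. Going by the values given here, on that basis a small rise in the number, possibly within the scatter, is expected, with wide uncertainty because the chloro group has no precedent here. The estimated step is a 1.8-fold higher number from compound 3 to compound 4 (0.25 log units; within the scatter). Compound 4 is expected to give 6.5 uM, between 2.5 uM and 17 uM.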

Compound 4, concentration for half-maximal effect: 1.37 uM
For compound 4 the middle estimate is 4.7-fold (0.68 log units) above the measured one; the whole stated range lies above it.
By their numbers in this assay, from the lowest: compound 4; then compound 3; then compounds 1 and 2 (each within the scatter of the next).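

In this assay, 3-chloro-4-methoxyphenyl in place of 3-methylphenyl, on the aromatic carbon next to the ring oxygen, gives a 2.7-fold lower number from compound 3 to compound 4 (0.43 log units; beyond the scatter). For the compounds shown here, this shows that the number at this position still moves downward from the lowest value seen among the earlier compounds, whereas the only earlier step on the pendant ring, a 1.7-fold higher number from compound 1 to compound 2 (0.22 log units; within the scatter), could not be told from the scatter; a pendant ring bearing both a chloro and a methoxy group, the larger of the two groups in this exchange, is therefore compatible with the lowest number in the set. No measured evidence bears on why the number falls with this change.

The compounds shown do not separate the contribution of the 3-chloro group from that of the 4-methoxy group, so the step can be read only for the pair taken together. Also open, going by these compounds, is how the number responds on this pendant ring to a dimethylamino group, a carboxylic acid or a trifluoromethyl group in the place of the chloro or methoxy group.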